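The source may hold more compounds than are shown below. What is called first, only, known or untested is meant among the compounds shown, and "the series" means these compounds.

The measured compounds are: compound 1, `Cc1ccccc1Nc1nc(NC2CC2)ncc1Cl`; compound 2, `CCN1CCN(c2ccc(Nc3ncc(Cl)c(Nc4ccccc4C)n3)nc2)CC1`; compound 3, `CN1CCN(c2ccc(Nc3ncc(Cl)c(NCc4ccc(C(F)(F)F)cc4)n3)nc2)CC1`.

In a functional assay on Jurkat cells (Homo sapiens) for inhibition, read by CCK-8 assay, with a stated time of 48 h (on this read-out lower numbers stand for stronger inhibition of growth and higher numbers for weaker inhibition of growth), compound 1 gives only a limit, > 100000 nM. Compound 2 likewise gives only a limit in this assay, > 100000 nM. For the measured compounds named here, compound 3 is the one compound with a number in this assay, 7960 nM. Compound 1 and compound 2 both sit at the limit of the assay, as the limit of > 100000 nM in this assay, at which 2 of the 3 values shown sit, records. Going by the values given here, no step between measured compounds differing in one place is available, so the size of single changes in this assay is not known from these data.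

The unmeasured compound 4, `CC(C)c1ccccc1Nc1nc(Nc2ccc(N3CCN(C)CC3)cn2)ncc1Cl`, differs from compound 3 in one place: 2-isopropylphenyl in place of 4-(trifluoromethyl)benzyl on a nitrogen on an aromatic ring. Compound 4 thereby shares its 2-substituted phenyl amine with compound 2, whose value in this assay is a limit. Because compound 2 gives > 100000 nM, the step from compound 3 to compound 4 is expected to weaken inhibition of growth, well beyond the scatter: a 7.5-fold higher number from compound 3 to compound 4 (0.88 log units; beyond the scatter). Compound 4 is therefore estimated at 60000 nM, with a range from 10000 nM to 150000 nM, and a real chance that the assay reports only a limit.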

Compound 4, concentration for 50% growth inhibition: 5140 nM
Compound 4: middle estimate off by 12-fold (1.07 log units), on the high side, outside the stated range (below it).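

In this assay, the exchange at this nitrogen gives a 1.5-fold lower number from compound 3 to compound 4 (0.19 log units; within the scatter), so 2-isopropylphenyl and 4-(trifluoromethyl)benzyl cannot be told apart here, although one is attached through a benzyl carbon and the other directly through its aromatic ring. A 2-substituted phenyl amine therefore does not by itself put a compound at the limit of this assay, as compound 4 carries one and still gives a number. Most of the values shown are still not numbers: the limit of > 100000 nM in this assay, at which 2 of the 4 values shown sit.

For the compounds shown here, compound 2 differs from compound 4 in more than one place, so no step between them can be read, and what separates its limit from the number of compound 4 stays open. Also open, as far as these compounds go, is how a cyclohexyl group or a longer chain, such as 2-phenylethyl, would read on this nitrogen.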